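A Stereocentre Left Undefined: Compound 2 to Compound 3

The compounds below may be only part of what the source reports. "The series", "measured", "known", "first", "only" and "open" are said of these compounds alone.

Measured so far:
compound 1 `CC(C)N(C(=O)CN1C=CN(c2ccccc2)C(=O)C(Cc2n[nH]c3ccccc23)C1=O)c1ccc(F)cc1` with 50.1 nM
compound 2 `CC(C)N(C(=O)CN1C=CN(c2ccccc2)C(=O)[C@H](Cc2n[nH]c3ccccc23)C1=O)c1ccccc1` with 295 nM

In a functional assay on CHO cells for agonist activity at Melanocyte-stimulating hormone receptor (Homo sapiens), read by a luciferase reporter, with a stated time of 4 h (on this read-out higher numbers stand for an effect only at larger amounts of compound and lower numbers for an effect already at smaller amounts), compound 2 gives the higher of the two numbers, while compound 1 gives 50.1 nM. Compound 3 `CC(C)N(C(=O)CN1C=CN(c2ccccc2)C(=O)C(Cc2n[nH]c3ccccc23)C1=O)c1ccccc1` is not yet measured. It differs from compound 2 only in that (the two compounds have the same atoms and bonds; at least one stereo element is drawn with a configuration in one of them and without one in the other: 1 of 1 stereo elements differ; a stereocentre at a saturated ring carbon is drawn R in compound 2 and without a configuration in compound 3). Since one of the two forms present in compound 3 is compound 2 itself, the step from compound 2 to compound 3 is expected to stay near the scatter, leaning either way. Compound 3 is therefore expected to give 200 nM, with a range of 60 nM to 650 nM, an expected step of a 1.5-fold lower number from compound 2 to compound 3 (0.17 log units; within the scatter).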

Compound 3, half-maximal effective concentration: 708 nM
Beside the measured number, compound 3's estimate is 3.5-fold (0.55 log units) below it; the whole stated range lies below it.
By their numbers in this assay, from the lowest: compound 1; then compound 2; then compound 3.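

In this assay, the step of a 2.4-fold higher number from compound 2 to compound 3 (0.38 log units; beyond the scatter) has only one structural difference to point to: the fact that one of compounds 2 and 3 is drawn with a defined configuration and the other without, at the place where they differ The configuration at this saturated ring carbon therefore matters to the read-out. With no configuration drawn on either compound, the large step of a 14-fold higher number from compound 1 to compound 3 (1.15 log units; beyond the scatter) isolates hydrogen in place of fluoro on an aromatic carbon, which the earlier pair, differing in two places, could not separate. Still open, on these data alone, is what the other form at the ring carbon gives on its own, and whether chloro or methoxy at that aromatic carbon would match fluoro.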